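Replacing chloro with methylamino on the shared core

The compounds below may be only part of what the source reports. "The series", "measured", "known", "first", "only" and "open" are said of these compounds alone.

Measured in a functional assay on HCT-116 cells (Homo sapiens) for antiproliferative activity, read by MTT assay, with a stated time of 48 h (on this read-out higher numbers stand for weaker inhibition and lower numbers for stronger inhibition), are these two compounds:
- Compound 1 `CCCCCC(CCO)n1cnc2c(Cl)ncnc21` gives > 50000 nM (a limit, not a number)
- Compound 2 `CCCCCCC(CCO)n1cnc2c(Cl)ncnc21` gives 11900 nM

Within the data shown here, compound 2 holds the only true number so far, so it cannot yet be ranked on a scale of measured values. Compound 3 `CCCCCCC(CCO)n1cnc2c(NC)ncnc21` keeps the chain of compound 2 and differs by methylamino in place of chloro on an aromatic carbon. Among the measured compounds shown here, the one measured step (an at least 4.2-fold lower number from compound 1 to compound 2 (0.62 log units; beyond the scatter)) lies on the chain, not at this place, so it bears only loosely: a single small edit can clearly shift the number. Like compound 1, compound 2 carries the chloro and gives 11900 nM with it, and no compound without chloro has been measured. In this assay a modest move toward weaker inhibition is therefore expected, and the estimated step is a 2.5-fold higher number from compound 2 to compound 3 (0.40 log units; beyond the scatter) (an expectation, not a result). Compound 3 is estimated at 30000 nM (expected range 11000 nM to 80000 nM).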

Compound 3, half-maximal inhibitory concentration: > 50000 nM
Compound 3: no number, only a limit; the forecaster's own chance of this, stated with the estimate: 40%; at least 1.6-fold (0.22 log units) between middle value and limit.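

In this assay, with the chain held fixed, methylamino in place of chloro on this aromatic carbon gives an at least 4.2-fold higher number from compound 2 to compound 3 (0.62 log units; beyond the scatter). This is the first change shown at this place, and it shows that the number responds to the group on the aromatic carbon as well as to the chain. Compound 3 gives > 50000 nM, which is a limit and not a number, so the full size of the step cannot be read: the limit of > 50000 nM in this assay, at which 2 of the 3 values shown sit.

With only one replacement for chloro shown, it remains open whether any other group on this carbon can match compound 2, at 11900 nM, or improve on it. A plain amine, a methoxy group or a bromine atom in place of chloro, each on the chain of compound 2, would help to settle this.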